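The source may hold more compounds than are shown below. What is called first, only, known or untested is meant among the compounds shown, and "the series" means these compounds.

Working notes on the series.

Compound 1 `C[C@@H](O[C@H]1CN2C(=O)C=C(c3ccc(CO)cc3)CC2[C@@H]1c1ccc(F)cc1)c1cc(C(F)(F)F)cc(C(F)(F)F)c1` is the reference point. Among the measured compounds shown here, in an assay on CHO cells for displacement of a labelled ligand from Substance-P receptor (Homo sapiens), in the presence of a further agent that is not named here (on this read-out higher numbers stand for weaker inhibition and lower numbers for stronger inhibition), compound 1 gives 23 nM, which is the highest number among the three compounds measured so far. Compound 2 `C[C@@H](O[C@H]1CN2C(=O)C=C(c3cc[nH]c(=O)c3)CC2[C@@H]1c1ccc(F)cc1)c1cc(C(F)(F)F)cc(C(F)(F)F)c1` carries a six-membered aromatic ring with one hetero atom in place of the carbon-only aromatic ring of compound 1, and in this assay compound 2 gives 3.9 nM. Compound 3 `C[C@@H](O[C@H]1CN2C(=O)C=C(c3ccc[n+]([O-])c3)CC2[C@@H]1c1ccc(F)cc1)c1cc(C(F)(F)F)cc(C(F)(F)F)c1` carries a different six-membered aromatic ring with one hetero atom, and in this assay compound 3 gives 2.3 nM. The steps from compound 1 are a 5.9-fold lower number from compound 1 to compound 2 (0.77 log units; beyond the scatter) and a 10-fold lower number from compound 1 to compound 3 (1.00 log units; beyond the scatter); between the two hetero-aromatic compounds the step is a 1.7-fold lower number from compound 2 to compound 3 (0.23 log units; within the scatter).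

Compound 4 `C[C@@H](O[C@H]1CN2C(=O)C=C(C3CCOCC3)CC2[C@@H]1c1ccc(F)cc1)c1cc(C(F)(F)F)cc(C(F)(F)F)c1` differs from compound 1 as follows: oxan-4-yl in place of 4-(hydroxymethyl)phenyl on a double-bonded ring carbon. Both measured steps from compound 1 concern a six-membered aromatic ring with one hetero atom entering in place of the carbon-only aromatic ring, and both lowered the number modestly. Nothing measured covers a six-membered non-aromatic ring entering at this position, so those steps bear only loosely on the change. The expectation for compound 4 is therefore a number near that of compound 1 or somewhat higher, with wide uncertainty, expected as a 2.2-fold higher number from compound 1 to compound 4 (0.34 log units; beyond the scatter). Compound 4 is estimated at 50 nM, in a range from 12 nM to 200 nM.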

Compound 4, half-maximal inhibitory concentration: 3.2 nM
The estimate for compound 4 lay 16-fold (1.19 log units) above the measured number; measured number below the stated range.
By their numbers in this assay, from the lowest: compounds 3, 4 and 2 (each within the scatter of the next); then compound 1.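

The step of a 7.2-fold lower number from compound 1 to compound 4 (0.86 log units; beyond the scatter) in this assay shows that an aromatic ring is not needed on this double-bonded ring carbon for the number to fall: oxan-4-yl, a six-membered non-aromatic ring, does so in place of 4-(hydroxymethyl)phenyl, and among the four compounds shown, compound 1, with its carbon-only aromatic ring, is the only one whose number stands apart. Neither step from the hetero-aromatic compounds separates compound 4 from them, a 1.4-fold higher number from compound 3 to compound 4 (0.14 log units; within the scatter) and a 1.2-fold lower number from compound 2 to compound 4 (0.09 log units; within the scatter), so aromatic and non-aromatic six-membered rings with 1 hetero atom cannot be told apart at this position in this assay. No supporting measurement is available to explain this result.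

Still open, going by these compounds, is whether the gap to compound 1 follows from the carbon-only ring or from its hydroxymethyl group, which leave together in every step; plain phenyl and cyclohexyl at this position would separate those two parts and test the ring oxygen of oxan-4-yl. Also open, on these data alone, is how this position responds to a piperidine ring amine, a carboxylic acid or a longer chain.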